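Methyl added on the aryl ring of compound 2

A few compounds are considered here, and "the series" means these few. Any claim that something is new, unique, unknown or untested is made for them only; others in the source may bear on it.

Of the compounds shown here, three have been measured in an assay on Sf9 cells for inhibition of protein deacetylase HDAC6 (Homo sapiens), read by fluorescence, with a stated time of 40 min, tested at 100 nM; a higher number here means more inhibition at the concentration tested (going by the name of the read-out), a lower number less inhibition. Compound 1 `O=C(NO)c1ccc(NCc2nc(-c3cccs3)nn2-c2ccc(O)cc2)cc1` gives 79.6%, compound 2 `Cc1cccc(-n2nc(-c3ccccc3)nc2CNc2ccc(C(=O)NO)cc2)c1` gives 66% and compound 3 `O=C(NO)c1ccc(NCc2nc(-c3ccc(Br)o3)nn2-c2ccccc2)cc1` gives 55.8%. On these numbers compound 2 stands second of the three: compound 3 sits beyond the scatter below it, and compound 1 sits beyond the scatter above it. Within the data shown here, no pair of measured compounds differs in one place only, so no single-point step is known.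

Compound 4 `Cc1ccc(-n2nc(-c3ccccc3)nc2CNc2ccc(C(=O)NO)cc2)cc1C` has not been measured. Its difference from compound 2 is methyl in place of hydrogen on an aromatic carbon: a methyl enters where a hydrogen leaves, on an aromatic carbon of the six-membered aromatic ring of carbon only, ortho to a methyl group and para to a large group; cut one bond further out, 3-methylphenyl becomes 3,4-dimethylphenyl. Among the measured compounds shown here, the measured compounds offer no step of comparable kind to lean on. A change of one heavy atom with no donors, no acceptors and no net charge is expected to move this assay by no more than the usual scatter, with no direction set by the data. Compound 4 is therefore estimated at 63%, within 47% to 78%. The expected step is a number 3 percentage points lower from compound 2 to compound 4 (within the scatter).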

Compound 4, a percentage reported as inhibition, at one concentration (the size of the read-out at that concentration, not a potency): 53%
Beside the measured number, compound 4's estimate is 10 percentage points above it; measured number inside the range.
By their numbers in this assay, from the lowest: compounds 4 and 3 (each within the scatter of the next); then compound 2; then compound 1.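

In this assay the series now has its first step at a single place: going from 3-methylphenyl to 3,4-dimethylphenyl gives a number 13 percentage points lower from compound 2 to compound 4 (beyond the scatter), so a methyl in place of hydrogen on this aromatic carbon, ortho to a methyl group and para to a large group, is not a silent change in this read-out. The step is modest and rests on one pair, so it marks this carbon as one where a single added carbon can lower inhibition at the tested concentration, but it sets no rule for other positions of the ring or for other compounds of the series. Nothing available accounts for the size or direction of the step.

From the compounds shown here alone, it remains open whether the loss belongs to the methyl itself or would follow any substituent on this carbon, such as a fluorine, a chlorine, a methoxy group or an amine. Going by these compounds, it also remains open whether the same methyl would lower the number on an aryl ring without the existing methyl group, or alongside a different group at the other end of the core.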